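The compounds below may be only part of what the source reports. "The series", "measured", "known", "first", "only" and "open" are said of these compounds alone.

Measured compounds:
compound 1 `COc1c(Br)cc(Br)cc1C(=O)Nc1cccc(Cl)c1`: in an assay on isolated protein for inhibition of thiosulfate sulfurtransferase (Homo sapiens), with a stated time of 60 min, in the absence of a further agent (on this read-out lower numbers stand for stronger inhibition and higher numbers for weaker inhibition), compound 1 gives > 100000 nM, a limit of the assay and not a number.
compound 2 `COc1c(Br)cc(Br)cc1C(=O)Nc1ccc(Sc2nc3ccccc3s2)c(Cl)c1`: in this assay compound 2 gives > 100000 nM, also a limit of the assay.

Within the data shown here, compound 1 therefore stands at a limit only; no number is known for it, and the one further value is a limit as well. Among the measured compounds shown here, the single measured step, a step that the two limits leave unreadable from compound 1 to compound 2, cannot be read, since both of its values sit at the limit of > 100000 nM in this assay, at which 2 of the 2 values shown sit. As far as these compounds go, its size and direction are unknown.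

Compound 3 `COc1ccc(Br)cc1C(=O)Nc1cccc(Cl)c1` differs from compound 1 by hydrogen in place of bromo on an aromatic carbon. For the measured compounds named here, no measured step bears on this change: the one step known is unreadable and concerns another place on the core of compound 1. The series gives no footing for a readable step from compound 1 to compound 3, so for compound 3 the expectation is that this assay again reports a limit, with no step beyond the scatter expected.

Compound 3 is estimated at 150000 nM, in a range from 30000 nM to 1000000 nM.

The expected step that the limit leaves unreadable from compound 1 to compound 3 is thus a guess rather than a prediction.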

Compound 3, half-maximal inhibitory concentration: > 100000 nM
Compound 3: only a limit was reported; the forecaster's own chance of this, stated with the estimate: 85%; the middle value is on the limit's open side.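

No step can be read from compound 1 to compound 3 in this assay, since both values are limits of the assay and not numbers: the limit of > 100000 nM in this assay, at which 3 of the 3 values shown sit.

The compounds shown leave open how strongly compound 1, compound 2 and compound 3 inhibit, and whether hydrogen in place of bromo shifts inhibition in either direction.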